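Swapping the amide aryl group on an inactive core

The source may report more compounds than this note shows. Statements on the series, on what has been measured and on what is new or still open speak of the compounds shown alone.

Compounds 1 and 2 share one core and differ only in the ring on the amide nitrogen. In a functional assay on A549 cells (Homo sapiens) for cytotoxicity, read by MTT assay, with a stated time of 72 h (on this read-out lower numbers stand for stronger inhibition and higher numbers for weaker inhibition), compound 1 `O=C(CN1CCN(c2nnc(Cc3ccncc3)c3ccccc23)CC1)Nc1ccc(F)c(F)c1` gives 3790 nM, and compound 2 `O=C(CN1CCN(c2nnc(Cc3ccncc3)c3ccccc23)CC1)Nc1ccc(Br)cc1` gives 2710 nM; the change of ring gives a 1.4-fold lower number from compound 1 to compound 2 (0.15 log units; within the scatter), so the two sit together. Compound 3 `Cc1ccc(F)cc1NC(=O)CN1CCN(c2nnc(Cc3ccccc3)c3ccccc23)CC1` has a different core and is reported in this assay only as "not active" (no number reported), with no number, so it stands apart from compounds 1 and 2 without a measured distance to them. Compound 4 `COc1ccc(NC(=O)CN2CCN(c3nnc(Cc4ccccc4)c4ccccc34)CC2)cc1OC` keeps the core of compound 3 and changes the amide ring: 3,4-dimethoxyphenyl in place of 5-fluoro-2-methylphenyl on an amide-type nitrogen. For the measured compounds named here, the one comparable step, between compounds 1 and 2, was within the scatter, but it sits on the other core and says nothing about whether a ring change on the core of compound 3 can bring a number back. Since compound 3 gave "not active" (no number reported), compound 4 is expected to stay weak, and the estimate for compound 4 in this assay is 20000 nM, within 5000 nM to 80000 nM.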

Compound 4, half-maximal inhibitory concentration: "not active" (no number reported)
Nothing numeric was reported for compound 4; no gap can be computed for the estimate.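

In this assay, for the compounds shown here, compound 3 gives "not active" (no number reported) and compound 4 gives "not active" (no number reported) with no number, so no step between these two compounds can be read. From the compounds shown here alone, whether any amide ring on this core can give a measurable number stays open. No measurement shown accounts for this result.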